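The source may hold more compounds than are shown below. What is called first, only, known or untested is meant among the compounds shown, and "the series" means these compounds.

Measured in an assay on HEK293 cells for displacement of a labelled ligand from metabotropic glutamate receptor 5 (Homo sapiens), with a stated time of 2 h; on this read-out lower numbers stand for stronger inhibition and higher numbers for weaker inhibition:

- compound 1 `CC(C)N1CCc2nc(C#Cc3ccc(Cl)cc3)ccc2C1=O` gives 27100 nM
- compound 2 `O=C1c2ccc(C#Cc3cccc(Cl)c3)nc2CCN1C1CCCC1` gives 5230 nM

Compound 2 stands at the lowest number of the two in this assay; compound 1 sits a good way higher, and the gap between them lies beyond the usual scatter of this read-out. For the measured compounds named here, no step between two measured compounds that differ in a single place is available, so the size of a single change is not fixed by any pair in hand.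

Compound 3 `O=C1c2ccc(C#Cc3ccc(Cl)cc3)nc2CCN1C1CCCC1` is the next member to be measured. It differs from compound 2 in one place: 4-chlorophenyl in place of 3-chlorophenyl on a triple-bonded carbon. Going by the values given here, compound 3 is expected to give a higher number than compound 2, with a step of a 2.9-fold higher number from compound 2 to compound 3 (0.46 log units; beyond the scatter) that is expected to exceed the scatter, because compound 1, the only other member carrying 4-chlorophenyl, gives 27100 nM. Since compound 1 and compound 3 differ elsewhere as well, the step is not expected to reach the full distance to compound 1. For compound 3 the estimated value in this assay is 15000 nM, within a range from 5000 nM to 45000 nM.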

Compound 3, inhibition constant: > 32000 nM
Compound 3 gave a limit, no number (the forecaster's own chance of this, stated with the estimate: 10%); middle value at least 2.1-fold (0.32 log units) from the limit.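

In this assay compound 3 gives > 32000 nM, which is a limit of the assay and not a number. With cyclopentyl held fixed on the amide-type nitrogen, the place of the chlorine on the phenyl ring alone moves the read-out, with 4-chlorophenyl in place of 3-chlorophenyl on a triple-bonded carbon giving weaker inhibition in a step that is at least modest and lies beyond the scatter: an at least 6.1-fold higher number from compound 2 to compound 3 (0.78 log units; beyond the scatter). The other new step, cyclopentyl in place of isopropyl on an amide-type nitrogen in a ring, is an at least 1.1-fold higher number from compound 1 to compound 3 (0.07 log units; that floor lies within the scatter), and it cannot be read, because the value behind it is only a limit: the limit of > 32000 nM in this assay, at which 1 of the 3 values shown sits.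

The full size of the chlorine shift stays open, as the step is bounded from one side only, and whether it holds with isopropyl on the nitrogen is untested by the compounds shown. Also open, as far as these compounds go, is how a 3-fluorophenyl, a 3-methylphenyl or a 3-methoxyphenyl on the triple-bonded carbon would compare with the 3-chlorophenyl of compound 2, and how a longer chain on the amide-type nitrogen would read.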